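This account rests on a few compounds, and the source may have more. Where it says the series, first, only, none or still open, it means among the compounds named here.

Measured compounds in an assay on isolated protein for binding affinity to Equilibrative nucleoside transporter 1 (Homo sapiens); a lower number here means a stronger inhibitor, a higher number a weaker inhibitor:
compound 1, `CCCCSc1nc(N)nc2c1ncn2[C@@H]1O[C@H](CO)[C@@H](O)[C@H]1O`: 12000 nM
compound 2, `Nc1nc(SCc2ccc(F)cc2)c2ncn([C@@H]3O[C@H](CO)[C@@H](O)[C@H]3O)c2n1`: 1150 nM

Going by the values given here, compound 2 stands at the lowest number of the two measured values, with compound 1 as its only neighbour. Among the compounds with values here, the single measured step at this position, a 10-fold lower number from compound 1 to compound 2 (1.02 log units; beyond the scatter), is large and shows that an aromatic ring on the saturated chain carbon bound to a sulfur is favoured over a plain chain there.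

Compound 3, `Nc1nc(SCc2ccccn2)c2ncn([C@@H]3O[C@H](CO)[C@@H](O)[C@H]3O)c2n1`, differs from compound 2 by pyridin-2-yl in place of 4-fluorophenyl on a saturated chain carbon bound to a sulfur. Within the data shown here, the one measured step bears on it only loosely: it swaps chain for ring, whereas this change keeps a six-membered aromatic ring and exchanges one such ring for another. Among the measured compounds shown here, no measured step tells how this assay responds to a ring swap of that kind. The step of a 1.7-fold higher number from compound 2 to compound 3 (0.24 log units; within the scatter) is therefore expected to be small, most likely within the scatter or a modest move to a higher number. Compound 3 is estimated at 2000 nM, in the range 600 nM to 7000 nM.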

Compound 3, half-maximal inhibitory concentration: 34700 nM
The estimate for compound 3 lay 17-fold (1.24 log units) below the measured number, and the stated range ends below it.
By their numbers in this assay, from the lowest: compound 2; then compound 1; then compound 3.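

In this assay the exchange of one six-membered aromatic ring for another on a saturated chain carbon bound to a sulfur is far from neutral: a 30-fold higher number from compound 2 to compound 3 (1.48 log units; beyond the scatter) shows that an aromatic ring alone does not secure a low number at this position. Pyridin-2-yl also compares poorly with the plain chain, with a 2.9-fold higher number from compound 1 to compound 3 (0.46 log units; beyond the scatter) in this series, so the preference for a ring over a chain holds for compound 2, and compound 3 goes against it. Nothing measured alongside these values explains the difference between the two rings.

The change removes the fluorine and places a nitrogen in the ring at once, and the compounds shown do not separate these two parts. An unsubstituted phenyl on the same chain carbon would show how much of the step belongs to each.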